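Piperidinylmethyl to thianyl on the amine arm

The compounds below may be only part of what the source reports. "The series", "measured", "known", "first", "only" and "open" are said of these compounds alone.

Measured so far:
compound 1 `c1ccc(CN(CCCCN(C[C@H]2Cc3ccccc3CN2)[C@H]2CCCc3cccnc32)Cc2ccccn2)nc1` gives 664 nM
compound 2 `c1cncc(CN(CCCCN(C[C@H]2Cc3ccccc3CN2)[C@H]2CCCc3cccnc32)Cc2cccnc2)c1` gives 471 nM
compound 3 `c1ccc2c(c1)CN[C@@H](CN(CCCCNCC1CCNCC1)[C@H]1CCCc3cccnc31)C2` gives 36.5 nM

All three were tested in a functional assay on cells for antagonist activity at C-X-C chemokine receptor type 4 (Homo sapiens), read by fluorescence and calcium flux, with stated times of 25 min and 90 s; a higher number here means a weaker inhibitor, a lower number a stronger inhibitor. Compound 3 holds the lowest number of the three; in this assay compound 3 gives 36.5 nM, and its gaps to compound 2 at 471 nM and to compound 1 at 664 nM both lie beyond the scatter. Compound 4 `c1ccc2c(c1)CN[C@@H](CN(CCCCNC1CCSCC1)[C@H]1CCCc3cccnc31)C2` differs from compound 3 in one place: thian-4-yl in place of (piperidin-4-yl)methyl on an amine nitrogen. Among the compounds with values here, no measured pair here shows a change of this kind, so its size is not known from these numbers. The expectation is a move toward a higher number, larger than the scatter. Compound 4 is therefore expected to give 300 nM, between 60 nM and 1500 nM. That amounts to an expected step of an 8.2-fold higher number from compound 3 to compound 4 (0.91 log units; beyond the scatter).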

Compound 4, half-maximal inhibitory concentration: 54.7 nM
The estimate for compound 4 lay 5.5-fold (0.74 log units) above the measured number; the measured number lies below the stated range.
By their numbers in this assay, from the lowest: compounds 3 and 4 (each within the scatter of the next); then compounds 2 and 1 (each within the scatter of the next).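

In this assay, putting thian-4-yl in place of (piperidin-4-yl)methyl on this amine nitrogen gives a 1.5-fold higher number from compound 3 to compound 4 (0.18 log units; within the scatter), so the two groups cannot be told apart here. The entering group has sulfur where the leaving group has nitrogen, and it carries no hydrogen-bond donor, so for this pair a donor on this arm is not needed to keep the number within the scatter. No evidence is available on what lies behind this result.

As far as these compounds go, the step changes the ring atom and removes the methyl link together, so the share of each stays open. A piperidin-4-yl group on the same nitrogen would separate the two.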